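Pyridin-3-yl in place of pyridin-4-yl on the shared core

The compounds below may be only part of what the source reports. "The series", "measured", "known", "first", "only" and "open" are said of these compounds alone.

For the measured compounds named here, compound 2 `Nc1nc(N2CCN(C(=O)COc3ccc(Cl)cc3)CC2)c2nc(-c3ccncc3)sc2n1` gives 40 nM in a functional assay on cells (Lymphocyte, Homo sapiens) (a lower number here means a stronger inhibitor, a higher number a weaker inhibitor), the lowest of the two numbers so far. Compound 1 `Nc1nc(N2CCN(C(=O)COc3ccc(Cl)cc3)CC2)c2nc(CCc3ccc(F)cc3)sc2n1` gives 4400 nM, and the step of a 110-fold lower number from compound 1 to compound 2 (2.04 log units; beyond the scatter) separates the pair. Compound 3 `Nc1nc(N2CCN(C(=O)COc3ccc(Cl)cc3)CC2)c2nc(-c3cccnc3)sc2n1` differs from compound 2 by pyridin-3-yl in place of pyridin-4-yl on an aromatic carbon. Going by the values given here, no measured step bears directly on this change: the single known step concerns pyridin-4-yl in place of 2-(4-fluorophenyl)ethyl and was large. For compound 3 a step of no more than the usual scatter is expected, a 2.0-fold higher number from compound 2 to compound 3 (0.30 log units; within the scatter). Compound 3 is therefore estimated at 80 nM, within 20 nM to 320 nM.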

Compound 3, half-maximal inhibitory concentration: 50 nM
For compound 3 the middle estimate is 1.6-fold (0.20 log units) above the measured one, within the range that was stated.
By their numbers in this assay, from the lowest: compounds 2 and 3 (each within the scatter of the next); then compound 1.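

In this assay, shifting the ring nitrogen from pyridin-4-yl to pyridin-3-yl on this aromatic carbon gives a 1.3-fold higher number from compound 2 to compound 3 (0.10 log units; within the scatter), so at this position the two pyridine isomers cannot be told apart. The large gain over 2-(4-fluorophenyl)ethyl is therefore not confined to pyridin-4-yl: the other isomer shows an 88-fold lower number from compound 1 to compound 3 (1.94 log units; beyond the scatter) as well. Nothing available gives a reason for either result.

Still open, as far as these compounds go, is whether a ring nitrogen is needed here at all, which plain phenyl at this position would address. Also open, from the compounds shown here alone, is whether pyridin-2-yl would match the other two isomers.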